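The source may report more compounds than this note shows. Statements on the series, on what has been measured and on what is new or still open speak of the compounds shown alone.

Compound 1, `NS(=O)(=O)c1ccc2c(c1)cc(C(=O)O)n2Cc1ccc(C(=O)O)cc1`, stands in the middle of the three compounds measured in an assay on cells (Oocyte) for inhibition of pannexin-1 (Mus musculus), read by voltage clamp, tested at 50 uM, in the presence of a further agent that is not named here; on this read-out lower numbers stand for less inhibition and higher numbers for more inhibition at the one concentration tested (going by the name of the read-out). In this assay compound 1 gives 61.7%. Compound 2, `O=C(O)c1ccc(Cn2c(C(=O)O)cc3cc(S(=O)(=O)N(Cc4ccccc4)Cc4ccccc4)ccc32)cc1`, gives 100% in this assay, a number that lies beyond the scatter above compound 1. Compound 3, `O=C(O)c1cn(CCCCCc2ccccc2)c2ccc([N+](=O)[O-])cc12`, gives 32.3% in this assay, which lies beyond the scatter below compound 1. For the measured compounds named here, compound 3 carries a nitro group, but its core and its other substituents differ from those of compound 1 in more than one place, so no single step connects it to compound 1.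

Compound 4, `O=C(O)c1ccc(Cn2c(C(=O)O)cc3cc([N+](=O)[O-])ccc32)cc1`, has not yet been measured in this assay. It differs from compound 1 in one place: nitro in place of sulfamoyl on an aromatic carbon.

Going by the values given here, no measured pair shows this change on this core, so the size of the step is open. Among the compounds with values here, the only nitro-bearing compound, compound 3, gives the lowest value with 32.3%, but its other differences prevent any direct reading. Compound 4 is therefore expected to give a value somewhat below compound 1, with the step from compound 1 to compound 4 estimated as a number 11.7 percentage points lower from compound 1 to compound 4 (beyond the scatter), perhaps not far beyond the scatter. For compound 4 the estimate in this assay is 50%, within a range of 25% to 75%.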

Compound 4, a percentage reported as inhibition, at one concentration (the size of the read-out at that concentration, not a potency): 61%
Beside the measured number, compound 4's estimate is 11 percentage points below it, within the range that was stated.
By their numbers in this assay, from the lowest: compound 3; then compounds 4 and 1 (each within the scatter of the next); then compound 2.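

In this assay, the change from sulfamoyl to nitro on this aromatic carbon of the shared core comes to a number 0.7 percentage points lower from compound 1 to compound 4 (within the scatter). At this position and at the one concentration tested, the two groups therefore cannot be told apart, even though nitro lacks the hydrogen-bond donor counted on sulfamoyl. Nothing in the data shown bears on why the two groups read alike.

The compounds shown leave open whether other groups on this aromatic carbon, such as an amine, a carboxylic acid or a plain hydrogen, would also fall within the scatter of compound 1, or whether the read-out on this core would move with a different group there. As the read-out comes from a single concentration, they also leave open whether compound 1 and compound 4 would still match across a range of concentrations, where a difference hidden at this one concentration could appear.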